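Alkoxy chain to cyclopentylmethoxy in TRPV1 urea series

The source may report more compounds than this note shows. Statements on the series, on what has been measured and on what is new or still open speak of the compounds shown alone.

Working notes on a small set of ureas sharing one core. Compound 2 `CCCCOc1nc(C(F)(F)F)ccc1CNC(=O)Nc1cccc2[nH]c(=O)ccc12` gives 4 nM in an assay on HEK cells for antagonist activity at transient receptor potential cation channel subfamily V member 1 (Homo sapiens), read by FLIPR (on this read-out higher numbers stand for weaker inhibition and lower numbers for stronger inhibition), the highest of the three numbers in hand. Compound 3 `CCCCCOc1nc(C(F)(F)F)ccc1CNC(=O)Nc1cccc2[nH]c(=O)ccc12` gives 2.72 nM, and the step of a 1.5-fold lower number from compound 2 to compound 3 (0.17 log units; within the scatter) is within the scatter. Compound 1 `O=C(NCc1ccc(C(F)(F)F)nc1N1CCC(Cc2ccccc2)CC1)Nc1cccc2[nH]c(=O)ccc12` gives 1.59 nM, a lower number than compound 2 by a margin beyond the scatter, but its change at the same position is not a single-site step and no comparison is drawn from it.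

Compound 4 `O=C(NCc1ccc(C(F)(F)F)nc1OCC1CCCC1)Nc1cccc2[nH]c(=O)ccc12` is not yet measured. It differs from compound 2 by cyclopentyl in place of propyl on a saturated chain carbon bound to an oxygen on an aromatic ring. Within the data shown here, the one measured step that bears on this, from compound 2 to compound 3, adds carbon to the chain and stays within the scatter. On that basis the expected step of a 1.4-fold lower number from compound 2 to compound 4 (0.15 log units; within the scatter) in this assay is small, leaning toward a slightly lower number, and may not exceed the scatter. Compound 4 is therefore estimated at 2.8 nM, with a range from 1.2 nM to 6.5 nM.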

Compound 4, half-maximal inhibitory concentration: 2.18 nM
Compound 4: the middle estimate sits 1.3-fold (0.11 log units) above what was measured; measured number inside the range.
By their numbers in this assay, from the lowest: compounds 1, 4, 3 and 2 (each within the scatter of the next, the first and the last beyond it).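

At the saturated chain carbon bound to an oxygen on an aromatic ring, the shared core also accepts a five-membered non-aromatic ring of carbon only in this assay: cyclopentyl in place of propyl gives a 1.8-fold lower number from compound 2 to compound 4 (0.26 log units; within the scatter), and cyclopentyl in place of butyl gives a 1.2-fold lower number from compound 3 to compound 4 (0.10 log units; within the scatter). Both steps lie within the scatter, so the read-out does not separate the cyclopentylmethoxy group of compound 4 from the open chains of compound 2 and compound 3. No supporting data on this result are available to interpret it further.

Open, on these data alone, is whether this position would read the same with a cyclopropyl ring, a phenyl ring or a much longer chain. Also open, as far as these compounds go, is the effect of an amine or a carboxylic acid at the end of the chain.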